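The source may report more compounds than this note shows. Statements on the series, on what has been measured and on what is new or still open speak of the compounds shown alone.

In an ADME assay on cells (Erythrocyte, Homo sapiens), read by spectrophotometry and hemolysis, with a stated time of 24 h (on this read-out lower numbers stand for stronger inhibition and higher numbers for weaker inhibition), compound 1 `N=C(N)N/N=C/c1ccc(OCc2ccc3no[n+]([O-])c3c2)cc1` gives > 200 uM as a limit of the assay. Compound 2 `O=Cc1ccccc1OCc1ccc2no[n+]([O-])c2c1` stands at > 100 uM as a limit of the assay, so the series offers no exact number yet. Compound 3 `CC(=O)c1ccccc1OCc1ccc2no[n+]([O-])c2c1` carries methyl in place of hydrogen on a carbonyl carbon, formyl to acetyl (methyl in place of hydrogen on a carbonyl carbon) relative to compound 2. Among the compounds with values here, no measured step bears on this change, so the expected step that the limit leaves unreadable from compound 2 to compound 3 in this assay is estimated as none beyond the scatter, in neither direction. Compound 3 is expected at 150 uM within an estimated range of 60 uM to 300 uM in this read-out.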

Compound 3, concentration for 50% inhibition: > 200 uM
Compound 3: only a limit was reported (the forecaster's own chance of this, stated with the estimate: 80%); middle value at least 1.3-fold (0.12 log units) away from the limit.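

Within the data shown here, the values of compound 2 and compound 3 are both limits, so no step between them can be read. The compounds shown leave open whether formyl to acetyl changes the exact value in this assay.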